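Estimating compound 3 from a single measured step

A few compounds are considered here, and "the series" means these few. Any claim that something is new, unique, unknown or untested is made for them only; others in the source may bear on it.

- compound 1 `COc1ccc(/C=C/c2cc(OC)c(OC)c(OC)c2-c2ccc(F)c(F)c2)cc1`: 9200 nM
- compound 2 `COc1ccc(/C=C/c2cc(OC)c(OC)c(OC)c2-c2ccc(Cl)cc2)cc1`: 49000 nM

In a functional assay on HeLa cells (Homo sapiens) for cytotoxicity, read by MTT assay, with a stated time of 48 h (a higher number here means a weaker inhibitor, a lower number a stronger inhibitor), compound 2 has the higher of the two numbers, which makes it the weaker inhibitor of this pair. Compound 3 `COc1ccc(/C=C/c2cc(OC)c(OC)c(OC)c2-c2ccc(F)c(C)c2)cc1` has not yet been measured. It differs from compound 2 in one place: 4-fluoro-3-methylphenyl in place of 4-chlorophenyl on an aromatic carbon. Within the data shown here, only one measured step bears on this change: a 5.3-fold higher number from compound 1 to compound 2 (0.73 log units; beyond the scatter). It is modest and involves the same place on the molecule. The entering 4-fluoro-3-methylphenyl resembles the 3,4-difluorophenyl of compound 1 more closely than it resembles 4-chlorophenyl, so compound 1, at 9200 nM, is the best guide. Among the measured compounds shown here, no measured compound shows the effect of the methyl group alone, so the expected shift is smaller than the measured step and uncertain. The expected change in this assay is a 2.7-fold lower number from compound 2 to compound 3 (0.43 log units; beyond the scatter). The estimated value for compound 3 is 18000 nM, within an expected range of 6000 nM to 50000 nM.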

Compound 3, half-maximal inhibitory concentration: 17000 nM
For compound 3 the middle estimate is 1.1-fold (0.02 log units) above the measured one; measured number inside the range.
By their numbers in this assay, from the lowest: compounds 1 and 3 (each within the scatter of the next); then compound 2.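

Measured in this assay the 4-fluoro-3-methylphenyl group in place of 4-chlorophenyl gives a 2.9-fold lower number from compound 2 to compound 3 (0.46 log units; beyond the scatter) and so a second ring, besides the 3,4-difluorophenyl of compound 1, now stands apart from the 4-chlorophenyl of compound 2 at this position. Methyl in place of fluoro on the ring gives a 1.8-fold higher number from compound 1 to compound 3 (0.27 log units; within the scatter) and this first view of that single change does not separate the two groups. No measured property of these compounds is available to explain either step.

Among these compounds, still open is whether compound 2 stands apart through its chloro group or through having only one substituent on the ring. Also open, going by these compounds, is how a ring carrying an amine, a carboxylic acid or a longer chain would behave at this position.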